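A few compounds are considered here, and "the series" means these few. Any claim that something is new, unique, unknown or untested is made for them only; others in the source may bear on it.

Compound 1 `C=CC(=O)NCc1ccc(C(=O)Nc2ccc(C)c(Nc3nccc(-c4cccnc4)n3)c2)cc1C(F)(F)F` gives > 10000 nM; compound 2 `Cc1ccc(NC(=O)c2ccc(CNC(=O)c3cccnc3)c(C(F)(F)F)c2)cc1Nc1nccc(-c2cccnc2)n1` gives 8330 nM; compound 3 `C=CC(=O)N(CCN(CC)CC)Cc1ccc(C(=O)Nc2ccc(C)c(Nc3nccc(-c4cccnc4)n3)c2)cc1` gives 5450 nM.

All three were tested in an ADME assay on BaF3 cells (Mus musculus) for cytotoxicity, read by CellTiter-Glo and CCK-8 assay, with a stated time of 72 h; a higher number here means a weaker inhibitor of growth, a lower number a stronger inhibitor of growth. For compound 1 the value > 10000 nM is a limit of the assay, not a number (the limit of > 10000 nM in this assay, at which 1 of the 3 values shown sits). Compound 2 differs from compound 1 by pyridin-3-yl in place of vinyl on a carbonyl carbon, and this produced an at least 1.2-fold lower number from compound 1 to compound 2 (0.07 log units; that floor lies within the scatter). The difference between the core of compound 3 and the core of compound 1 is not broken down here. Compound 4 `CCN(CC)CCN(Cc1ccc(C(=O)Nc2ccc(C)c(Nc3nccc(-c4cccnc4)n3)c2)cc1)C(=O)c1cccnc1` is not yet measured; it differs from compound 3 by pyridin-3-yl in place of vinyl on a carbonyl carbon, the same change that was made from compound 1 to compound 2. Because that earlier step was an at least 1.2-fold lower number from compound 1 to compound 2 (0.07 log units; that floor lies within the scatter), a similarly small step is expected for compound 4, namely a 1.2-fold higher number from compound 3 to compound 4 (0.08 log units; within the scatter). Compound 4 is therefore estimated at 6500 nM in this assay, plausibly between 2500 nM and 16000 nM.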

Compound 4, concentration for 50% growth inhibition: > 10000 nM
Compound 4 ended at the assay's limit; the forecaster's own chance of this, stated with the estimate: 25%; at least 1.5-fold (0.18 log units) between middle value and limit.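

In this assay compound 4 gives > 10000 nM and that is a limit of the assay, not a number. Pyridin-3-yl in place of vinyl on a carbonyl carbon gave an at least 1.8-fold higher number from compound 3 to compound 4 (0.26 log units; that floor lies within the scatter) on this core. Neither step has a fixed size, so the data show neither that the change carries over from one core to the other nor that it fails to: the same change on two cores in this assay, an at least 1.2-fold lower number (0.07 log units; that floor lies within the scatter) from compound 1 to compound 2 and an at least 1.8-fold higher number (0.26 log units; that floor lies within the scatter) from compound 3 to compound 4; the limit leaves it open whether they differ.

On these data alone, the true size of the step on either core stays open, and so does any wider reading of the series: the limit of > 10000 nM in this assay, at which 2 of the 4 values shown sit. Also open, as far as these compounds go, is whether a cyclopropyl or a phenyl group in place of vinyl on a carbonyl carbon would give numbers on both cores that could be set side by side.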